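This account rests on a few compounds, and the source may have more. Where it says the series, first, only, none or still open, it means among the compounds named here.

Measured in a functional assay on A549 cells (Homo sapiens) for inhibition, read by MTT assay, with a stated time of 72 h; on this read-out higher numbers stand for weaker inhibition and lower numbers for stronger inhibition:
- compound 1 `COc1ccc(-c2nnc(SCCCN3CCN(c4nc5ccccc5o4)CC3)o2)cc1`: 93500 nM
- compound 2 `O=[N+]([O-])c1ccc(-c2nnc(SCCCN3CCN(c4nc5ccccc5o4)CC3)o2)cc1`: 90800 nM

Compound 2, at 90800 nM, cannot be separated from compound 1, at 93500 nM, so the two values form a single level in this series. The next compound, compound 3 `Cc1ccc(-c2nnc(SCCCN3CCN(c4nc5ccccc5o4)CC3)o2)cc1`, has methyl in place of nitro on an aromatic carbon, para to a large group: methyl in place of nitro on an aromatic carbon. Among the compounds with values here, the only measured step bearing on this change is nitro in place of methoxy on an aromatic carbon, a 1.0-fold lower number from compound 1 to compound 2 (0.01 log units; within the scatter). Within the data shown here, no measured compound carries methyl at this place, so that single step is the only guide. No step beyond the scatter is therefore expected in this assay, in either direction. The expected step is a 1.0-fold lower number from compound 2 to compound 3 (0.00 log units; within the scatter). Compound 3 is estimated at 90000 nM, with an expected range of 50000 nM to 160000 nM.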

Compound 3, half-maximal inhibitory concentration: 106000 nM
Compound 3: the middle estimate sits 1.2-fold (0.07 log units) below what was measured; the measured number falls inside the stated range.
By their numbers in this assay, from the lowest: compounds 2, 1 and 3 (each within the scatter of the next).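

In this assay the third group at this place gives no separation: the change to methyl reads a 1.2-fold higher number from compound 2 to compound 3 (0.07 log units; within the scatter) and the change from methoxy to methyl reads a 1.1-fold higher number from compound 1 to compound 3 (0.05 log units; within the scatter) on the same ring carbon. Methoxy, nitro and methyl therefore form one level across compounds 1, 2 and 3, so the earlier single step now has two further steps beside it. Replacing the nitro group, with 3 heavy atoms and 2 hydrogen-bond acceptors, by methyl, with 1 heavy atom and no hydrogen-bond acceptors, leaves the number within the scatter, and nothing on hand explains this flat result.

Open, going by these compounds, is whether an amine, a carboxylic acid or a longer chain at this place would give a step beyond the scatter. The compounds shown also say nothing about changes elsewhere on the shared core, so this level cannot yet be tied to any one part of the structure.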